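The source may report more compounds than this note shows. Statements on the series, on what has been measured and on what is new or still open speak of the compounds shown alone.

Measured compounds:
Compound 1, `CCCCCCCCCCCCNC(=O)[C@@H](NC(=O)c1cc2ccccc2n1C)[C@@H](C)O`: in a functional assay on HepG2 cells (Homo sapiens) for cytotoxicity, read by MTT assay, with a stated time of 48 h (a higher number here means a weaker inhibitor, a lower number a stronger inhibitor), compound 1 gives > 200000 nM, which is a limit of the assay and not a number.
Compound 2, `CCCCCCCCCCCCCCCCCCNC(=O)[C@@H](NC(=O)c1cc2ccccc2[nH]1)[C@@H](C)O`: in this assay compound 2 gives 89400 nM.

Within the data shown here, compound 2 therefore stands as the only compound with a numerical value in this assay; the other entry is a limit, (the limit of > 200000 nM in this assay, at which 1 of the 2 values shown sits). Compound 3, `CCCCCCCCCCCCCCCCCCNC(=O)[C@@H](NC(=O)c1cc2ccccc2n1C)[C@@H](C)O`, has not yet been measured there. It differs from compound 2 in one place: methyl in place of hydrogen on an aromatic nitrogen. Among the measured compounds shown here, no measured pair covers this change on its own, so the size of the step can only be guessed. For the measured compounds named here, the one compound that already carries the methyl on the aromatic nitrogen, compound 1, reaches only the limit > 200000 nM in this assay, which is weaker than the number of compound 2, though that comparison also involves a different chain. On that basis compound 3 is expected to be weaker than compound 2, by a step of a 1.8-fold higher number from compound 2 to compound 3 (0.25 log units; within the scatter) that goes beyond the usual scatter. Compound 3 is thus estimated at 160000 nM, within a range from 60000 nM to 400000 nM, with a fair chance that only a limit is reported.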

Compound 3, half-maximal inhibitory concentration: > 200000 nM
Compound 3: a limit, no number; the forecaster's own chance of this, stated with the estimate: 40%; at least 1.2-fold (0.09 log units) between middle value and limit.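

Among these compounds, for the first time, the change from hydrogen to methyl on the aromatic nitrogen stands on its own in this assay, and it weakens the compound, with the long chain held fixed: an at least 2.2-fold higher number from compound 2 to compound 3 (0.34 log units; beyond the scatter). Compound 3 gives > 200000 nM, which is a limit and not a number, so this step fixes only the smallest size the change can have, not its full size. The step that puts hexyl on the chain of compound 1 cannot be read, and limits now make up most of the set: the limit of > 200000 nM in this assay, at which 2 of the 3 values shown sit.

On these data alone, what remains open is how far the true value of compound 3 lies past its limit, and whether the shorter dodecyl chain would also give a readable number once the hydrogen is back on the aromatic nitrogen. As far as these compounds go, whether an ethyl or an acetyl group on that nitrogen would behave as methyl does also stays open.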